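A few compounds are considered here, and "the series" means these few. Any claim that something is new, unique, unknown or untested is made for them only; others in the source may bear on it.

Compound 1 `Cc1ccccc1C(=O)NN(C(=O)c1ccccc1Cl)C(C)(C)C`: 72.4 nM
Compound 2 `CC(C)(C)N(NC(=O)c1cccc(C#N)c1)C(=O)c1ccccc1Cl`: 955 nM
Compound 3 `CC(C)(C)N(NC(=O)c1ccc(I)cc1)C(=O)c1ccccc1Cl`: 7.59 nM

These three compounds share one core and differ only in the aromatic ring attached to one of the two carbonyl carbons. All were tested in an assay on cells for agonist activity at ecdysone receptor (Bombyx mori), read by a luciferase reporter, with a stated time of 24 h; on this read-out higher numbers stand for an effect only at larger amounts of compound and lower numbers for an effect already at smaller amounts. Compound 3 gives the lowest number of the three, at 7.59 nM. The step of a 9.5-fold lower number from compound 1 to compound 3 (0.98 log units; beyond the scatter) separates it from compound 1, and the step of a 130-fold lower number from compound 2 to compound 3 (2.10 log units; beyond the scatter) separates it from compound 2, so compound 3 stands clearly apart from both.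

Compound 4 `CC(C)(C)N(NC(=O)c1ccc(C#N)cc1)C(=O)c1ccccc1Cl` has not been measured. Compared with compound 3 it carries cyano in place of iodo on an aromatic carbon. Within the data shown here, two measured steps bear on this change. In a 130-fold lower number from compound 2 to compound 3 (2.10 log units; beyond the scatter) a cyano left and iodo entered, although that cyano sat at a different position on the ring. In a 9.5-fold lower number from compound 1 to compound 3 (0.98 log units; beyond the scatter) a methyl left and iodo entered. Both steps point to the iodo-bearing ring giving the lowest numbers. Reversing the exchange, with cyano replacing iodo, the number is therefore expected to rise, though perhaps not by the full amount seen with compound 2.

Compound 4 is expected to give about 300 nM, within a range of 60 nM to 1500 nM, which corresponds to an expected step of a 40-fold higher number from compound 3 to compound 4 (1.60 log units; beyond the scatter).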

Compound 4, half-maximal effective concentration: 603 nM
Estimate against measurement, compound 4: 2.0-fold (0.30 log units) below; the range from low to high includes it.
By their numbers in this assay, from the lowest: compound 3; then compound 1; then compounds 4 and 2 (each within the scatter of the next).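

In this assay, exchanging iodo for cyano on the same ring gives a 79-fold higher number from compound 3 to compound 4 (1.90 log units; beyond the scatter). Among these compounds, this is the first comparison in which the group changes while its place on the ring stays fixed. Moving the nitrile from the 3-cyanophenyl to the 4-cyanophenyl arrangement gives a 1.6-fold lower number from compound 2 to compound 4 (0.20 log units; within the scatter), so the two cyano rings cannot be told apart here, and among these compounds the low number belongs to the 4-iodophenyl ring alone rather than to substitution at that place in general. The step of an 8.3-fold higher number from compound 1 to compound 4 (0.92 log units; beyond the scatter) also leaves the 2-methylphenyl ring in the middle of the series, though no measurement shown explains why these rings differ.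

Still open, from the compounds shown here alone, is where other groups at this place would fall, for instance a 4-bromophenyl, 4-methoxyphenyl or 4-aminophenyl ring, and so whether iodo is unusual or simply one of many groups that give low numbers. Also open, going by these compounds, is whether a 3-iodophenyl ring would stay close to the 4-iodophenyl ring, as the two cyano rings do, or would lie well away from it.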